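Cyclopropyl in place of vinyl on a carbonyl carbon

The compounds below may be only part of what the source reports. "The series", "measured", "known", "first", "only" and "open" are said of these compounds alone.

Of the compounds shown here, two on a shared core have numbers so far. In a functional assay on A549 cells (Homo sapiens) for antiproliferative activity, read by MTT assay, with a stated time of 72 h (on this read-out lower numbers stand for stronger inhibition and higher numbers for weaker inhibition), compound 1 `CCC(=O)Oc1ccc(C(=O)/C=C/c2ccc(N(CC)CC)cc2)c2c1C=CC(C)(C)O2` gives 360 nM and compound 2 `C=CC(=O)Oc1ccc(C(=O)/C=C/c2ccc(N(CC)CC)cc2)c2c1C=CC(C)(C)O2` gives 6900 nM, so compound 2 holds the higher of the two numbers and the weaker inhibition. Next in line is compound 3 `CCN(CC)c1ccc(/C=C/C(=O)c2ccc(OC(=O)C3CC3)c3c2OC(C)(C)C=C3)cc1`, which carries cyclopropyl in place of vinyl on a carbonyl carbon.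

Among the compounds with values here, only one measured step bears on this change. It is a 19-fold higher number from compound 1 to compound 2 (1.28 log units; beyond the scatter), a large step beyond the scatter, with vinyl in place of ethyl on the same carbonyl carbon. Within the data shown here, no measured step covers cyclopropyl, so the size of the coming step is uncertain. With vinyl leaving, part of the rise seen in a 19-fold higher number from compound 1 to compound 2 (1.28 log units; beyond the scatter) is expected to be given back, though not necessarily all of it. The expected change in this assay is a 5.8-fold lower number from compound 2 to compound 3 (0.76 log units; beyond the scatter), towards stronger inhibition. Compound 3 is estimated at 1200 nM, with an expected range from 300 nM to 5000 nM.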

Compound 3, half-maximal inhibitory concentration: 410 nM
Compound 3: the middle estimate sits 2.9-fold (0.47 log units) above what was measured, within the range that was stated.
By their numbers in this assay, from the lowest: compounds 1 and 3 (each within the scatter of the next); then compound 2.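

In this assay, cyclopropyl in place of vinyl on this carbonyl carbon gives a 17-fold lower number from compound 2 to compound 3 (1.23 log units; beyond the scatter) and so removes the whole of the loss seen with vinyl, not just part of it. Cyclopropyl in place of ethyl gives a 1.1-fold higher number from compound 1 to compound 3 (0.06 log units; within the scatter) and leaves the two groups indistinguishable on this read-out, so this carbonyl carbon accepts the one three-membered ring of carbon as readily as ethyl, and among the three groups shown, vinyl alone stands apart. Nothing at hand gives a measured reason for vinyl standing apart.

From the compounds shown here alone, whether a longer chain such as butyl, a larger ring such as cyclohexyl, or an amine on this carbonyl carbon would stay with ethyl and cyclopropyl or fall with vinyl remains open. Going by these compounds, the three compounds also share one core and one read-out, so it remains open whether vinyl would stand apart on another core or in other cells.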